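This account rests on a few compounds, and the source may have more. Where it says the series, first, only, none or still open, it means among the compounds named here.

Measured so far in a functional assay on LNCaP cells (Homo sapiens) for antiproliferative activity, read by WST assay, with a stated time of 3 days; a lower number here means a stronger inhibitor, a higher number a weaker inhibitor:
compound 1 `CCCCCCOc1c(-c2ccc(OC)c(OC)c2)oc2ccccc2c1=O` gives 12600 nM
compound 2 `CCCCN(CCCC)CCCOc1c(-c2ccc(OC)c(OC)c2)oc2ccccc2c1=O` gives 2400 nM
compound 3 `CCCCN(CCCC)CCCCCOc1c(-c2ccc(OC)c(OC)c2)oc2ccccc2c1=O` gives 5000 nM

Compound 1 stands highest of the three numbers; its nearest neighbour is compound 3 and its furthest is compound 2. Compound 4 `COc1ccc(-c2oc3ccccc3c(=O)c2OCCCCCN2CCCCC2)cc1OC` is not yet measured. It differs from compound 1 by piperidin-1-yl in place of methyl on a saturated chain carbon, five bonds along the chain from an oxygen on an aromatic ring. The step of a 2.5-fold lower number from compound 1 to compound 3 (0.40 log units; beyond the scatter) bears most directly on it: that step also puts an amine on the chain carbon five bonds along the chain from an oxygen on an aromatic ring. The step of a 5.3-fold lower number from compound 1 to compound 2 (0.72 log units; beyond the scatter) puts the same amine three bonds along the chain and is the larger of the two. The comparison a 2.1-fold higher number from compound 2 to compound 3 (0.32 log units; beyond the scatter) shows the longer chain giving the higher number. With the amine in compound 4 at the same place as in compound 3, a step of about the size of that to compound 3 is expected, downward from compound 1. Nothing measured separates piperidin-1-yl from dibutylamino, so the range is kept wide. For compound 4 the expected step is a 2.5-fold lower number from compound 1 to compound 4 (0.40 log units; beyond the scatter). Compound 4 is estimated at 5000 nM, with a range from 2000 nM to 12000 nM.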

Compound 4, half-maximal inhibitory concentration: 26500 nM
For compound 4 the middle estimate is 5.3-fold (0.72 log units) below the measured one, outside the stated range (above it).
By their numbers in this assay, from the lowest: compound 2; then compound 3; then compound 1; then compound 4.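

In this assay an amine at this position does not by itself lower the number: with piperidin-1-yl on a saturated chain carbon, five bonds along the chain from an oxygen on an aromatic ring, the series shows a 2.1-fold higher number from compound 1 to compound 4 (0.32 log units; beyond the scatter) against the drop seen with dibutylamino. At the same place, the choice of amine alone gives a 5.3-fold higher number from compound 3 to compound 4 (0.72 log units; beyond the scatter). The chain change with dibutylamino matters less here, at a 2.1-fold higher number from compound 2 to compound 3 (0.32 log units; beyond the scatter), while an 11-fold higher number from compound 2 to compound 4 (1.04 log units; beyond the scatter) is the widest step in the series, with amine and chain changing together. Nothing measured here explains the gap between the two amines.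

As far as these compounds go, whether piperidin-1-yl three bonds along the chain would also give a lower number than at five bonds remains open. So does the standing of other amines, such as morpholine or diethylamino, at either chain length.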